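The source may hold more compounds than are shown below. What is called first, only, known or untested is meant among the compounds shown, and "the series" means these compounds.

Measured compounds:

Compound 1, `CCCCCCCCNC(=O)[C@@H](NC(=O)c1cccs1)[C@@H](C)O`: 136000 nM
Compound 2, `CCCCCCCCNC(=O)[C@@H](NC(=O)c1cc2ccccc2o1)[C@@H](C)O`: 200000 nM
Compound 3, `CCCCCCCCCCCCCCCCCCNC(=O)[C@@H](NC(=O)c1cccs1)[C@@H](C)O`: 200000 nM

All three were tested in a functional assay on SW-620 cells (Homo sapiens) for cytotoxicity, read by MTT assay, with a stated time of 48 h; a higher number here means a weaker inhibitor, a lower number a stronger inhibitor. Compound 1 gives 136000 nM, compound 2 gives 200000 nM, and compound 3 gives 200000 nM. Compound 2 differs from compound 1 by 1-benzofuran-2-yl in place of thiophen-2-yl on a carbonyl carbon, and the step this made is a 1.5-fold higher number from compound 1 to compound 2 (0.17 log units; within the scatter). Compound 3 differs from compound 1 in its core, by decyl in place of hydrogen on a saturated chain carbon, eight bonds along the chain from an amide-type nitrogen, and here the step is a 1.5-fold higher number from compound 1 to compound 3 (0.17 log units; within the scatter). The numbers of compound 2 and compound 3 agree at the digits given.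

Compound 4, `CCCCCCCCCCCCCCCCCCNC(=O)[C@@H](NC(=O)c1cc2ccccc2o1)[C@@H](C)O`, has not yet been measured in this assay. It differs from compound 3 by 1-benzofuran-2-yl in place of thiophen-2-yl on a carbonyl carbon. This is the same change that turns compound 1 into compound 2, and the place is described in the same words for both pairs, so the change counts as the same one made on a different core. Because the earlier step of a 1.5-fold higher number from compound 1 to compound 2 (0.17 log units; within the scatter) stayed within the scatter, the step from compound 3 to compound 4 is expected to be small as well, estimated at a 1.3-fold higher number from compound 3 to compound 4 (0.10 log units; within the scatter). This rests on a single earlier pair only, so the expectation is loose. Compound 4 is therefore estimated to give 250000 nM in this assay, with a plausible range from 120000 nM to 500000 nM.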

Compound 4, half-maximal inhibitory concentration: > 200000 nM
Compound 4: no number, only a limit (the forecaster's own chance of this, stated with the estimate: 35%); the middle value lies beyond the limit too.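

In this assay compound 4 gives > 200000 nM, which is a limit of the assay and not a number. The change from thiophen-2-yl to 1-benzofuran-2-yl gives a number no lower from compound 3 to compound 4 (the limit leaves the size open), but the sizes of both new steps cannot be read, so this result does not show whether the change carries over to a second core with the same effect: the same change on two cores in this assay, a 1.5-fold higher number (0.17 log units; within the scatter) from compound 1 to compound 2 and a number no lower (the limit leaves the size open) from compound 3 to compound 4; the limit leaves it open whether they differ. The same caution applies to decyl in place of hydrogen on the chain, which was also carried to a second core and there gives a number no lower from compound 2 to compound 4 (the limit leaves the size open): the same change on two cores in this assay, a 1.5-fold higher number (0.17 log units; within the scatter) from compound 1 to compound 3 and a number no lower (the limit leaves the size open) from compound 2 to compound 4; the limit leaves it open whether they differ.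

The compounds shown leave open whether a different group on the carbonyl carbon, such as phenyl or an aminophenyl group, would give a clearly lower number in this assay. They also leave open what an amine or a carboxylic acid on the saturated chain would do.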